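The source may report more compounds than this note shows. Statements on the series, on what has been measured and on what is new or still open speak of the compounds shown alone.

Measured so far:
Compound 1, `Cn1nc(COc2cc(F)cc(F)c2)c2c1CCN(C(=O)Nc1ccc(Br)cc1)C2`: 3300 nM
Compound 2, `Cn1nc(COc2cc(F)cc(F)c2)c2c1CCN(C(=O)NC(=O)c1ccccc1)C2`: > 10000 nM

In an assay on cells for inhibition of Pendrin (Mus musculus), read by fluorescence, with a stated time of 10 min (on this read-out higher numbers stand for weaker inhibition and lower numbers for stronger inhibition), compound 1 gives 3300 nM. Compound 2 sits at the limit of this assay, > 10000 nM, so for it only a limit is known and not a number (the limit of > 10000 nM in this assay, at which 1 of the 2 values shown sits). Among the measured compounds shown here, the one measured step, an at least 3.0-fold higher number from compound 1 to compound 2 (0.48 log units; beyond the scatter), puts benzoyl in place of 4-bromophenyl on an amide-type nitrogen and weakens inhibition.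

Compound 3, `CC(C)NC(=O)N1CCc2c(c(COc3cc(F)cc(F)c3)nn2C)C1`, differs from compound 2 by isopropyl in place of benzoyl on an amide-type nitrogen. For the measured compounds named here, no measured step covers a change from benzoyl to isopropyl, so the only guide is that compound 2 already sits at the limit of this assay. The expectation for compound 3 in this assay is therefore a number near that limit, with a real chance that again only a limit is reported. The expected step is a number no higher from compound 2 to compound 3 (the limit leaves the size open). Compound 3 is estimated at 10000 nM, between 3000 nM and 30000 nM.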

Compound 3, half-maximal inhibitory concentration: > 10000 nM
Compound 3 gave a limit, no number (the forecaster's own chance of this, stated with the estimate: 60%); the middle value sits exactly at the limit.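

In this assay compound 3 gives > 10000 nM, which is a limit and not a number. Putting isopropyl in place of 4-bromophenyl on the amide-type nitrogen gives an at least 3.0-fold higher number from compound 1 to compound 3 (0.48 log units; beyond the scatter), so a small open chain with no ring, like benzoyl before it, does not keep the measurable inhibition of compound 1. The step between compound 2 and compound 3 cannot be read, so benzoyl and isopropyl cannot be ranked, and the same limit now holds both compounds: the limit of > 10000 nM in this assay, at which 2 of the 3 values shown sit.

The compounds shown leave open whether the inhibition of compound 1 depends on the bromine or on the aromatic ring that carries it. A plain phenyl or a chlorophenyl on the same amide-type nitrogen would separate those two possibilities.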